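The source may report more compounds than this note shows. Statements on the series, on what has been measured and on what is new or still open speak of the compounds shown alone.

Measured compounds and their values in a functional assay on HCT-116 cells (Homo sapiens) for inhibition, read by MTT assay, with a stated time of 72 h, tested at 20 uM; a lower number here means less inhibition, a higher number more inhibition at the concentration tested (going by the name of the read-out):

compound 1, `CNC(=O)c1cc(Oc2ccc(Nc3nccc(N4CCCC4)n3)cc2)ccn1`: compound 1 gives 66.4%
compound 2, `c1cc(N2CCCCC2)nc(Nc2ccc(Oc3ncnc4sccc34)cc2)n1`: compound 2 gives 66.3%
compound 3, `CN(c1ccc(Oc2ncnc3ccsc23)cc1)c1nccc(N2CCCC2)n1`: compound 3 gives 63.6%

Compound 3 holds the lowest of the three numbers in this assay, but its gap to compound 2 and its gap to compound 1 both lie within the usual scatter of repeated measurements, so the three readings are not distinguishable and no ranking among them is supported. All three share an arylamino-pyrimidine motif carrying a saturated nitrogen ring, with compounds 2 and 3 also sharing the same bicyclic aryl ether.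

Compound 4, `CN(c1ccc(Oc2ncnc3ccsc23)cc1)c1nccc(N2CCCCC2)n1`, differs from compound 3 in one place: piperidin-1-yl in place of pyrrolidin-1-yl on an aromatic carbon

Within the data shown here, no measured pair in this set isolates that exact change, so no step size is available from the data. What can be said is that compound 2, which carries piperidin-1-yl, and compound 3, which carries pyrrolidin-1-yl, read within the scatter of each other in this assay, with compound 2 giving 66.3% and compound 3 giving 63.6%. On that basis the expected step from the change to compound 4 is none beyond the scatter, in either direction: a number 0.4 percentage points higher from compound 3 to compound 4 (within the scatter) is the estimated step. Compound 4 is therefore expected to give about 64% in this assay, with a likely range from 51% to 77%.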

Compound 4, a percentage reported as inhibition, at one concentration (the size of the read-out at that concentration, not a potency): 66.2%
Beside the measured number, compound 4's estimate is 2.2 percentage points below it; the measured number falls inside the stated range.
By their numbers in this assay, from the lowest: compounds 3, 4, 2 and 1 (each within the scatter of the next).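

In this assay, among these compounds, piperidin-1-yl in place of pyrrolidin-1-yl on the aromatic carbon next to the ring nitrogen gives a number 2.6 percentage points higher from compound 3 to compound 4 (within the scatter), and this is the first pair in which the ring size at this position is the only difference. Compound 2 and compound 3 had left that change mixed with other differences, whereas here the rest of the molecule is held fixed and the five-membered and six-membered rings cannot be told apart at the concentration tested. Nothing available bears on why the two rings read alike.

What the compounds shown leave open is whether this position accepts more than these two saturated nitrogen rings: a morpholine ring, a dimethylamino group or a primary amine on the same carbon would extend the comparison beyond ring size alone. Going by these compounds, the readings are also percentages at one concentration and not potencies, so any difference between compound 3 and compound 4 in a full concentration-response measurement remains unknown.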